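The source may report more compounds than this note shows. Statements on the series, on what has been measured and on what is new or still open speak of the compounds shown alone.

Compound 1 `CCOC(=O)CCCCCOc1cccc(CN(C(=O)c2ccc(-c3cccc(-c4nnc(C)o4)c3)cc2)C(C)C)c1` gives, as a limit of the assay, > 26000 nM in an ADME assay on HepG2 cells (Homo sapiens) for cytotoxicity, read by CellTiter-Glo and resazurin assay, with a stated time of 72 h; a lower number here means that less compound is needed, a higher number that more compound is needed for the effect.
Compound 2 `CCOC(=O)CCCCCOc1cccc(CN(C(=O)c2ccc(-c3cc(F)cc(OC)c3)cc2)C(C)C)c1` gives, likewise as a limit, > 26000 nM in this assay.

Compound 2 thus stands only at a limit in this assay, and a step that the two limits leave unreadable from compound 1 to compound 2 cannot be read from the two limits. For the measured compounds named here, the one step on record is this unreadable one, and the limit of > 26000 nM in this assay, at which 2 of the 2 values shown sit, sets the frame. Compound 3 `CCOC(=O)CCCCCOc1cccc(CN(C(=O)c2ccc(-c3cccc(F)c3)cc2)C(C)C)c1` differs from compound 2 by hydrogen in place of methoxy on an aromatic carbon. With both measured values sitting at the limit, no shift beyond the scatter can be foreseen, and the expected step that the limit leaves unreadable from compound 2 to compound 3 is taken as flat. Compound 3 is therefore estimated at 30000 nM, within 13000 nM to 100000 nM, most likely again reported as a limit.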

Compound 3, half-maximal effective concentration: > 26000 nM
Compound 3 was reported as a limit (the forecaster's own chance of this, stated with the estimate: 80%); the middle value does not contradict the limit.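

For the compounds shown here, no step among compound 1, compound 2 and compound 3 can be read in this assay, since each value is only a limit: the limit of > 26000 nM in this assay, at which 3 of the 3 values shown sit.
The compounds shown leave open how far each compound's true value lies from that limit, and whether any change at this place would give a readable value.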